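Removing a Methyl: From Compound 2 to Compound 3

The source may hold more compounds than are shown below. What is called first, only, known or untested is meant among the compounds shown, and "the series" means these compounds.

Compound 1: `Cc1cnn(C(=O)N2CCN(C(c3ccc4ccccc4c3)c3ccc4ccccc4c3)CC2)c1`, 260 nM
Compound 2: `Cc1cnn(C(=O)N2CCN(C(c3ccc(OCc4ccccc4)cc3)c3ccc(OCc4ccccc4)cc3)CC2)c1`, 2100 nM

In an assay on membranes from brain for binding affinity to Monoglyceride lipase (Mus musculus), read by fluorescence, with stated times of 1 h and 30 min (a lower number here means a stronger inhibitor, a higher number a weaker inhibitor), compound 1 gives 260 nM. In this assay compound 2 gives 2100 nM, the highest of the two numbers, and its gap to compound 1 lies beyond the scatter.

Compound 3, `O=C(N1CCN(C(c2ccc(OCc3ccccc3)cc2)c2ccc(OCc3ccccc3)cc2)CC1)n1cccn1`, differs from compound 2 by one change: hydrogen in place of methyl on an aromatic carbon. Going by the values given here, no pair of measured compounds shows this change, so its effect is unknown. Only a small step is expected, in no direction beyond the scatter; the expected step is a 1.2-fold higher number from compound 2 to compound 3 (0.09 log units; within the scatter). Compound 3 is estimated at 2600 nM, within 1000 nM to 6500 nM.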

Compound 3, half-maximal inhibitory concentration: 3900 nM
Compound 3: the middle estimate sits 1.5-fold (0.18 log units) below what was measured; measured number inside the range.
By their numbers in this assay, from the lowest: compound 1; then compounds 2 and 3 (each within the scatter of the next).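

In this assay the change from 4-methyl-1H-pyrazol-1-yl to 1H-pyrazol-1-yl gives a 1.9-fold higher number from compound 2 to compound 3 (0.27 log units; within the scatter) and so stays within the scatter. Going by these compounds alone, at this position, the methyl therefore makes no readable difference in this pair, which is the first reading of this change. Nothing measured here offers an explanation for this result.

On these data alone, it remains open whether an amine or a longer chain on this aromatic carbon would shift the number. As far as these compounds go, it is also open whether the same change would read alike on the core of compound 1.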